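Tolerance of the chlorophenyl-to-pyridyl swap at the piperazine nitrogen

The compounds below may be only part of what the source reports. "The series", "measured", "known", "first", "only" and "open" are said of these compounds alone.

Measured so far:
compound 1 `COc1cc(Cc2cnc(/N=C3\C(=O)N(CN4CCN(Cc5ccccc5)CC4)c4ccc(Cl)cc43)nc2N)cc(OC)c1OC` — 94.7 ug/mL
compound 2 `CCCCN(CCCC)CN1C(=O)/C(=N\c2ncc(Cc3cc(OC)c(OC)c(OC)c3)c(N)n2)c2cc(Cl)ccc21` — "not determined" (no result reported)
compound 3 `COc1cc(Cc2cnc(/N=C3\C(=O)N(CN4CCN(c5cccc(Cl)c5)CC4)c4ccc(Cl)cc43)nc2N)cc(OC)c1OC` — 34.4 ug/mL

In an ADME assay on CCRF-CEM cells (Homo sapiens) for cytotoxicity, read by MTT assay, with a stated time of 5 days (a higher number here means that more compound is tolerated, a lower number that less compound is tolerated), compound 3 gives 34.4 ug/mL, the lowest of the two numbers in hand; its nearest neighbour is compound 1, with 94.7 ug/mL. For compound 2 this assay records "not determined" (no result reported), so no number is in hand for it.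

Compound 4 `COc1cc(Cc2cnc(/N=C3\C(=O)N(CN4CCN(c5ccccn5)CC4)c4ccc(Cl)cc43)nc2N)cc(OC)c1OC` differs from compound 3 in one place: pyridin-2-yl in place of 3-chlorophenyl on an amine nitrogen in a ring. Among the compounds with values here, the only measured step that bears on this position is a 2.8-fold lower number from compound 1 to compound 3 (0.44 log units; beyond the scatter), where an aryl group directly on the ring nitrogen replaced a benzyl group. The step from compound 3 to compound 4 keeps an aromatic ring directly on that nitrogen and removes the chlorine, exchanging it for a ring nitrogen. Nothing in hand quantifies that exchange on its own, so the expectation rests on compound 3 and a step no larger than the one already seen, tending back toward compound 1 rather than further down.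

Compound 4 is therefore expected to give 45 ug/mL in this assay, with a range of 20 ug/mL to 100 ug/mL, which corresponds to an estimated step of a 1.3-fold higher number from compound 3 to compound 4 (0.12 log units; within the scatter), a shift that may well sit within the scatter.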

Compound 4, half-maximal cytotoxic concentration: 29.4 ug/mL
The estimate for compound 4 lay 1.5-fold (0.18 log units) above the measured number; low and high end bracket the measured number.
By their numbers in this assay, from the lowest: compounds 4 and 3 (each within the scatter of the next); then compound 1.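

In this assay, pyridin-2-yl in place of 3-chlorophenyl on the amine nitrogen in the ring gives a 1.2-fold lower number from compound 3 to compound 4 (0.07 log units; within the scatter), so this position accepts a carbon-only aromatic ring bearing chlorine or an aromatic ring with one hetero atom without separating the two compounds. Pyridin-2-yl in place of benzyl gives a 3.2-fold lower number from compound 1 to compound 4 (0.51 log units; beyond the scatter), and this second step beyond the scatter stands alongside a 2.8-fold lower number from compound 1 to compound 3 (0.44 log units; beyond the scatter), so among these three compounds both ring replacements for benzyl part from compound 1 to a similar extent. No evidence in hand accounts for these steps or for the closeness of the two ring replacements.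

The compounds shown leave open how an unsubstituted phenyl, or a small alkyl group such as methyl, would stand at this nitrogen, and so whether the chlorine and the ring nitrogen matter at all on their own. Also open, as far as these compounds go, is whether a longer chain linking the aromatic ring to that nitrogen would keep the number near that of compound 1 at 94.7 ug/mL in this assay or carry it further from the pair of compound 3 and compound 4.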